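Swapping the Phenyl Group on a Carbonyl Carbon

The source may report more compounds than this note shows. Statements on the series, on what has been measured and on what is new or still open speak of the compounds shown alone.

Compound 1 `COc1ccc(C(=O)N2CCN(CC(=O)N3CCN(CCCc4c[nH]c5ccccc45)CC3)CC2)cc1`: 148000 nM
Compound 2 `O=C(CN1CCN(C(=O)c2cccc(Cl)c2)CC1)N1CCN(CCCc2c[nH]c3ccccc23)CC1`: 120000 nM

In an ADME assay on SH-SY5Y cells (Homo sapiens) for cytotoxicity, read by MTT assay, with a stated time of 72 h (on this read-out lower numbers stand for stronger inhibition and higher numbers for weaker inhibition), compound 2 gives 120000 nM, level with compound 1 at 148000 nM, since the two values lie within the usual scatter of repeated measurements. Only these two numbers are available so far, so compound 2 has just one neighbour to be compared with.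

The next compound is compound 3 `O=C(CN1CCN(C(=O)c2ccccc2F)CC1)N1CCN(CCCc2c[nH]c3ccccc23)CC1`, which differs from compound 2 in a single place: 2-fluorophenyl in place of 3-chlorophenyl on a carbonyl carbon. In words, 2-fluorophenyl stands in place of 3-chlorophenyl on a carbonyl carbon, while the rest of the molecule stays the same.

For the measured compounds named here, one measured step bears on this change, as it also swaps the group on that carbonyl carbon: a 1.2-fold lower number from compound 1 to compound 2 (0.09 log units; within the scatter). Going by the values given here, that step stayed within the scatter, and it is the only evidence available, so no step beyond the scatter is expected here. The expected change is a 1.0-fold higher number from compound 2 to compound 3 (0.02 log units; within the scatter).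

Compound 3 is estimated at 125000 nM, with an expected range from 65000 nM to 230000 nM.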

Compound 3, half-maximal inhibitory concentration: 82600 nM
Estimate against measurement, compound 3: 1.5-fold (0.18 log units) above, within the range that was stated.
By their numbers in this assay, from the lowest: compounds 3, 2 and 1 (each within the scatter of the next).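

Compound 3 adds a third substituted phenyl group on this carbonyl carbon, and the reading in this assay still does not separate the compounds: the result is a 1.5-fold lower number from compound 2 to compound 3 (0.16 log units; within the scatter) and, over the larger distance, a 1.8-fold lower number from compound 1 to compound 3 (0.25 log units; within the scatter), so both steps remain inside the normal spread of repeat measurements. The second step matters most, since it shows that even the two compounds furthest apart in this set, carrying 4-methoxyphenyl and 2-fluorophenyl, cannot be told apart here, so among these three compounds 3-chlorophenyl, 2-fluorophenyl and 4-methoxyphenyl all read as level and none goes against that picture. No measured property of these groups is available to account for this result.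

All three groups shown are phenyl rings carrying a single substituent, so these compounds say nothing about how the reading would respond if an amine, a carboxylic acid or a longer chain stood on this carbonyl carbon instead. From the compounds shown here alone, it also remains open whether a phenyl ring with no substituent at all, or one with two chlorine atoms, would stay level with these three compounds.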